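This account rests on a few compounds, and the source may have more. Where it says the series, first, only, none or still open, it means among the compounds named here.

Measured in a functional assay on blood (Homo sapiens), with a stated time of 60 min, in the presence of a further agent that is not named here; on this read-out higher numbers stand for an effect only at larger amounts of compound and lower numbers for an effect already at smaller amounts:
- compound 1 `O=C(Oc1ccccc1)C1(S(=O)(=O)c2ccc(Oc3ccc(OC(F)(F)F)cc3)cc2)CCC2(CCNCC2)C1`: 900 nM
- compound 2 `O=C(Nc1nccs1)C1(S(=O)(=O)c2ccc(Oc3ccc(OC(F)(F)F)cc3)cc2)CCC2(CCNCC2)C1`: > 15000 nM (a limit of the assay, not a number)
- compound 3 `O=C1CN(C(=O)C2(S(=O)(=O)c3ccc(Oc4ccc(OC(F)(F)F)cc4)cc3)CCC3(CCNCC3)C2)CCN1`: 7500 nM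

Of the two true numbers, the higher belongs to compound 3, with 7500 nM. For the measured compounds named here, the only other true number belongs to compound 1, with 900 nM.

The next structure is compound 4 `O=C(Nc1ccccc1O)C1(S(=O)(=O)c2ccc(Oc3ccc(OC(F)(F)F)cc3)cc2)CCC2(CCNCC2)C1`, which has (2-hydroxyphenyl)amino in place of 3-oxopiperazin-1-yl on a carbonyl carbon.

Two measured changes at this same carbonyl carbon bear on it. Putting 3-oxopiperazin-1-yl in place of phenoxy gave an 8.3-fold higher number from compound 1 to compound 3 (0.92 log units; beyond the scatter), and (1,3-thiazol-2-yl)amino in place of phenoxy gave an at least 16-fold higher number from compound 1 to compound 2 (1.22 log units; beyond the scatter). Exchanging those two nitrogen-linked groups gave an at least 2.0-fold lower number from compound 2 to compound 3 (0.30 log units; that floor lies within the scatter). Compound 4 also has a nitrogen-linked group there, so it is expected to resemble compound 3 and compound 2 more than compound 1, given an 8.3-fold higher number from compound 1 to compound 3 (0.92 log units; beyond the scatter). No step beyond the scatter is therefore expected in this assay.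

The expected change is a 1.3-fold lower number from compound 3 to compound 4 (0.10 log units; within the scatter). For compound 4 the estimate is 6000 nM, with an expected range from 1800 nM to 15000 nM.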

Compound 4, half-maximal effective concentration: > 15000 nM
Compound 4: a limit, no number; the forecaster's own chance of this, stated with the estimate: 20%; middle value at least 2.5-fold (0.39 log units) from the limit.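

In this assay, compound 4 sits at a limit of the assay, > 15000 nM, and that limit is not a number. Against the phenoxy group, (2-hydroxyphenyl)amino on this carbonyl carbon gives a large step, an at least 16-fold higher number from compound 1 to compound 4 (1.22 log units; beyond the scatter), so all three nitrogen-linked groups shown now give higher numbers than phenoxy, with none going against this. The comparison with the 3-oxopiperazin-1-yl group gives an at least 2.0-fold higher number from compound 3 to compound 4 (0.30 log units; that floor lies within the scatter), so these two groups cannot be placed in an order.

As far as these compounds go, the step between the two aromatic amide groups of compound 2 and compound 4 cannot be read, because both values sit at the same limit: the limit of > 15000 nM in this assay, at which 2 of the 4 values shown sit. Also open is what phenylamino, which lacks the hydroxyl, or a methoxy group would give on this carbonyl carbon.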